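Chain-linked propargylamine replacing a piperazine on the shared core

This account rests on a few compounds, and the source may have more. Where it says the series, first, only, none or still open, it means among the compounds named here.

Measured compounds:
compound 1 `C#CCNCc1cn(-c2cc(NC(=S)NCC)ncn2)cn1` gives 5240 nM in an assay on isolated protein for inhibition of Amine oxidase [flavin-containing] B (Homo sapiens), read by fluorescence and Amplex Red, with a stated time of 15 min; on this read-out lower numbers stand for stronger inhibition and higher numbers for weaker inhibition;
compound 2 `C#CCN1CCN(Cc2cn(-c3cc(NC(=S)NCC)ncn3)cn2)CC1` gives > 50000 nM in this assay.

Compound 2 sits at the limit of this assay (the limit of > 50000 nM in this assay, at which 1 of the 2 values shown sits), and its value is only a limit, not a number. Compound 3 `C#CCNCCCc1cn(-c2cc(NC(=S)NCC)ncn2)cn1` differs from compound 2 by 2-(propargylamino)ethyl in place of 4-propargylpiperazin-1-yl on a saturated chain carbon bound to an aromatic carbon. Within the data shown here, the one measured step that bears on this, an at least 9.5-fold higher number from compound 1 to compound 2 (0.97 log units; beyond the scatter), runs the other way: compound 1 carried the propargylamino group on a single chain carbon. Compound 3 restores that group on a longer chain, so a large downward step from compound 2 is expected, estimated at an at least 3.3-fold lower number from compound 2 to compound 3 (0.52 log units; beyond the scatter). Compound 3 is expected to give about 15000 nM, between 4000 nM and 50000 nM.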

Compound 3, half-maximal inhibitory concentration: > 50000 nM
Compound 3 ended at the assay's limit (the forecaster's own chance of this, stated with the estimate: 25%); middle value at least 3.3-fold (0.52 log units) away from the limit.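

Moving the propargylamino group from the single chain carbon of compound 1 onto the longer 2-(propargylamino)ethyl chain gives an at least 9.5-fold higher number from compound 1 to compound 3 (0.97 log units; beyond the scatter). So removing the piperazine ring does not by itself bring back a measurable value in this assay, and of these three compounds only compound 1 gives a number. The step from compound 2 to compound 3 cannot be read, because each of them gives only a limit: the limit of > 50000 nM in this assay, at which 2 of the 3 values shown sit.

As far as these compounds go, what stays open is whether a methyl group on the amine nitrogen of compound 1 would keep a measurable value. From the compounds shown here alone, how much chain the propargylamino group tolerates before the value reaches the limit also remains unknown.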